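Adding chloro to a well-tolerated benzothiazolyl thioether amide

The source may report more compounds than this note shows. Statements on the series, on what has been measured and on what is new or still open speak of the compounds shown alone.

Compound 1, `COc1ccc(Br)cc1C(=O)Nc1ccc(Sc2nc3ccccc3s2)cc1`, was examined in an ADME assay on HEK293 cells (Homo sapiens) for cytotoxicity, read by reporter gene assay and resazurin assay, with a stated time of 48 h; a lower number here means that less compound is tolerated, a higher number that more compound is tolerated. In this assay compound 1 gives > 100000 nM, which is a limit of the assay and not a number. Its companion compound 2, `COc1c(Br)cccc1C(=O)Nc1ccc(Sc2nc3ccccc3s2)cc1`, was examined in the same way. In this assay compound 2 gives > 100000 nM, again a limit rather than a number. Among the measured compounds shown here, the single step between them, a step that the two limits leave unreadable from compound 1 to compound 2, is therefore of no readable size, and the limit of > 100000 nM in this assay, at which 2 of the 2 values shown sit, is all that the two values offer. Compound 3, `COc1ccc(Br)cc1C(=O)Nc1ccc(Sc2nc3ccccc3s2)c(Cl)c1`, differs from compound 1 by chloro in place of hydrogen on an aromatic carbon. For the measured compounds named here, no measured step bears on this change, so nothing in this assay points to a direction beyond the scatter, and the two limits show only that both measured compounds sit at the limit. Compound 3 is therefore expected to give about 100000 nM, within 30000 nM to 300000 nM. The expected step, a number no higher from compound 1 to compound 3 (the limit leaves the size open), is thus estimated to be none beyond the scatter.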

Compound 3, half-maximal cytotoxic concentration: > 100000 nM
Compound 3 ended at the assay's limit; the forecaster's own chance of this, stated with the estimate: 85%; the middle value sits exactly at the limit.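

In this assay, among the compounds shown here, compound 1 and compound 3 both stand at a limit and not at a number, and no step between them can be read. The compounds shown leave open at what concentration any of them ceases to be tolerated, and whether chloro in place of hydrogen alters that concentration.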